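Taking the methoxycarbonyl off compound 2

The source may report more compounds than this note shows. Statements on the series, on what has been measured and on what is new or still open speak of the compounds shown alone.

Of the compounds shown here, three built on one shared core have been tested so far in an ADME assay on HEK293 cells (Homo sapiens) for cytotoxicity, read by MTT assay, with a stated time of 24 h (on this read-out higher numbers stand for lower toxicity in this test and lower numbers for higher toxicity in this test), and none of them has yet given a number. Compound 2 (`COC(=O)C1CN(c2nc(=O)c3cc(C(F)(F)F)cc([N+](=O)[O-])c3s2)CCC12OC[C@H](C)O2`) reads > 10000 nM in this test, which is a limit of the assay and not a number. Compound 1 (`CN(C(=O)CN1CCN(c2nc(=O)c3cc(C(F)(F)F)cc([N+](=O)[O-])c3s2)CC1)c1ccccc1`) reads > 10000 nM and this too is a limit. Compound 3 (`O=c1nc(N2CCC(F)(F)CC2)sc2c([N+](=O)[O-])cc(C(F)(F)F)cc12`) reads > 10000 nM and this is also a limit. Compound 2 therefore has no rank among the three, and the whole record is the limit of > 10000 nM in this assay, at which 3 of the 3 values shown sit, for now.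

Compound 4 (`C[C@H]1COC2(CCN(c3nc(=O)c4cc(C(F)(F)F)cc([N+](=O)[O-])c4s3)CC2)O1`) is compound 2 with a single change: hydrogen in place of methoxycarbonyl on a saturated ring carbon. Going by the values given here, no measured pair of compounds differs in one place, so no measured step can serve as a guide. The methoxycarbonyl is absent from compound 3, which still reads > 10000 nM as a limit. No step beyond the usual scatter is therefore expected. The estimate is a step that the limit leaves unreadable from compound 2 to compound 4 and it stays within that scatter. Another limit is the likeliest report. For compound 4 the estimated value is 15000 nM with an expected range from 6000 nM to 40000 nM on this read-out.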

Compound 4, half-maximal cytotoxic concentration: > 10000 nM
Compound 4 ended at the assay's limit (the forecaster's own chance of this, stated with the estimate: 80%); the middle value is on the limit's open side.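

Going by these compounds alone, compound 2 and compound 4 both read as a limit in this assay and not as a number, so no step between them can be read. The compounds shown leave open how toxic any of them is in this test, and whether any change to the shared core would give a measurable number, as the whole record is one value: the limit of > 10000 nM in this assay, at which 4 of the 4 values shown sit.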